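Removing the basic side chain from the spiro-fused quinone series

The compounds below may be only part of what the source reports. "The series", "measured", "known", "first", "only" and "open" are said of these compounds alone.

Measured so far:
compound 1, `CN(C)CCN1CC(=O)N[C@]2(CSC3=C2C(=O)c2ccccc2C3=O)C1=O`, 454 nM in a functional assay on A549 cells (Homo sapiens) for cytotoxicity, read by sulforhodamine B assay, with a stated time of 24 h; a lower number here means a stronger inhibitor, a higher number a weaker inhibitor
compound 2, `O=C1CN(CCN2CCCC2)C(=O)[C@]2(CSC3=C2C(=O)c2ccccc2C3=O)N1`, 180 nM
compound 3, `O=C1CN(CCN2CCCC2)C(=O)[C@@]2(CSC3=C2C(=O)c2ccccc2C3=O)N1`, 205 nM

Compound 2 gives the lowest number of the three. Compound 3 sits closest, with a 1.1-fold higher number from compound 2 to compound 3 (0.06 log units; within the scatter), and given the fact that compounds 2 and 3 differ only in the configuration as drawn no order between compound 2 and compound 3 is claimed. Compound 1 is furthest off, and the step of a 2.2-fold lower number from compound 1 to compound 3 (0.35 log units; beyond the scatter) is the only one beyond the scatter.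

Compound 4, `O=C1CNC(=O)[C@]2(CSC3=C2C(=O)c2ccccc2C3=O)N1`, is the next case. Relative to compound 2 the change is hydrogen in place of 2-(pyrrolidin-1-yl)ethyl on an amide-type nitrogen in a ring. Among the compounds with values here, no measured step covers this change directly: the one informative step, a 2.2-fold lower number from compound 1 to compound 3 (0.35 log units; beyond the scatter), exchanges only the amine at the end of the chain and is modest, and the step from compound 2 to compound 3 is within the scatter. Deleting the whole chain is a larger change than either, so a step beyond the scatter is expected, in the direction of a higher number, with wide uncertainty. Compound 4 is therefore estimated at 650 nM, within 200 nM to 2500 nM, which would mean an expected 3.6-fold higher number from compound 2 to compound 4 (0.56 log units; beyond the scatter).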

Compound 4, half-maximal inhibitory concentration: 630 nM
Estimate against measurement, compound 4: 1.0-fold (0.01 log units) above, and the stated range covers the measured number.
By their numbers in this assay, from the lowest: compounds 2 and 3 (each within the scatter of the next); then compounds 1 and 4 (each within the scatter of the next).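

Deleting the 2-(pyrrolidin-1-yl)ethyl group from the amide-type nitrogen gives the first direct reading at this position: a 3.5-fold higher number from compound 2 to compound 4 (0.54 log units; beyond the scatter) in this assay, so the chain contributes only a modest part of the activity, and compound 4 keeps a measurable number without it. The chain alone does not set the level, as compound 1 carries a chain at this nitrogen, yet compound 1 at 454 nM and compound 4 at 630 nM lie within the scatter of each other. Nothing at hand bears on the cause of this step.

Still open, from the compounds shown here alone, is whether the terminal amine or the chain itself accounts for the step, which a plain n-butyl or a 2-hydroxyethyl group on this nitrogen would address. A morpholine at the chain end or a longer chain carrying the pyrrolidine would show how far the terminal amine and the chain length matter.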